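The source may hold more compounds than are shown below. What is called first, only, known or untested is meant among the compounds shown, and "the series" means these compounds.

Measured so far:
Compound 1 `Cc1ccc(C(=O)NN(C(=O)c2ccccc2Cl)C(C)(C)C)cc1` — 18.6 nM
Compound 2 `Cc1ccc(C(=O)NN(C(=O)c2cc(C)cc(C)c2)C(C)(C)C)cc1` — 12 nM
Compound 3 `Cc1cc(C)cc(C(=O)NN(C(=O)CCCC(C)C)C(C)(C)C)c1` — a limit, > 100000 nM

In an assay on cells for agonist activity at ecdysone receptor (Bombyx mori), read by a luciferase reporter, with a stated time of 24 h (on this read-out lower numbers stand for an effect already at smaller amounts and higher numbers for an effect only at larger amounts of compound), compound 2 gives the lowest of the two numbers shown, and compound 1 stands nearest to it. The step of a 1.6-fold lower number from compound 1 to compound 2 (0.19 log units; within the scatter) is within the scatter, so the two compounds cannot be ranked against each other. Compound 3 reaches only a limit in this assay and gives no number.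

Compound 4 `CCCCCCCC(=O)NN(C(=O)c1cc(C)cc(C)c1)C(C)(C)C` is not yet measured. Its difference from compound 2 is heptyl in place of 4-methylphenyl on a carbonyl carbon. Within the data shown here, no measured step involves exactly this exchange. Among the measured compounds shown here, the only measured step, from compound 1 to compound 2, swaps one aromatic ring for another and is small. For the measured compounds named here, compound 3, the one compound here with an open chain on a carbonyl carbon rather than a ring, sits at the limit of > 100000 nM in this assay, at which 1 of the 3 values shown sits; its value shows the weakest effect among the three, though no single-place step connects it to compound 2.

On this basis the heptyl chain in compound 4 is expected to cost a great deal, with a large step upward a 2500-fold higher number from compound 2 to compound 4 (3.40 log units; beyond the scatter) and a real chance that compound 4 gives only a limit. Compound 4 is estimated at 30000 nM, within a range from 1000 nM to 100000 nM.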

Compound 4, half-maximal effective concentration: 97.7 nM
Compound 4: middle estimate off by 310-fold (2.49 log units), on the high side; measured number below the stated range.
By their numbers in this assay, from the lowest: compounds 2 and 1 (each within the scatter of the next); then compound 4. At a limit, above all of these: compound 3.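

In this assay the exchange of the 4-methylphenyl ring for a heptyl chain on a carbonyl carbon gives an 8.1-fold higher number from compound 2 to compound 4 (0.91 log units; beyond the scatter) and so marks a real but modest loss, the first step shown that changes this position. An aromatic ring is therefore not strictly needed here: heptyl has the same number of heavy atoms but no ring, and compound 4 still gives a measured number rather than a limit. This does not settle how open chains behave in general, since compound 3 differs from compound 4 in more than one place and stays at a limit that cannot be read as the effect of a chain at this position: the limit of > 100000 nM in this assay, at which 1 of the 4 values shown sits.

The compounds shown leave open whether the step comes from losing the ring itself or its aromatic character, which cyclohexyl could help separate, and whether it depends on chain length, as butyl or decyl could show. They also leave open whether a chain ending in an amine or a carboxylic acid would be tolerated here, and whether heptyl has a similar effect with 2-chlorophenyl in place of 3,5-dimethylphenyl.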